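Iodo in Place of Chloro on a Shared Core

The source may report more compounds than this note shows. Statements on the series, on what has been measured and on what is new or still open speak of the compounds shown alone.

Compound 1 `Cn1c([N+](=O)[O-])cnc1/C=C/c1ccccc1Cl` and compound 3 `Cn1c([N+](=O)[O-])cnc1/C=C/c1ccccc1I` differ by iodo in place of chloro on an aromatic carbon. In an ADME assay on HeLa cells (Homo sapiens) for cytotoxicity, read by resazurin assay, with a stated time of 2 days (on this read-out lower numbers stand for stronger inhibition and higher numbers for weaker inhibition), compound 1 gives only a limit of the assay, > 100000 nM. Compound 3 likewise gives only a limit, > 100000 nM. The step that the two limits leave unreadable from compound 1 to compound 3 cannot be sized because of the limit of > 100000 nM in this assay, at which 2 of the 3 values shown sit.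

Compound 2 `Cn1c([N+](=O)[O-])cnc1/C=C/c1cccc(Cl)c1` has the same atoms as compound 1 joined differently; the difference between the two cores is not broken down here. In this assay, among the measured compounds shown here, compound 2 gives 30200 nM, the only number among the three values.

Compound 4 `Cn1c([N+](=O)[O-])cnc1/C=C/c1cccc(I)c1` differs from compound 2 by iodo in place of chloro on an aromatic carbon. This is the same kind of change as that from compound 1 to compound 3, but in compound 4 the place is meta to a large group, whereas in compound 3 it is ortho to a large group. Since the measured pair yields no readable step, the expectation for compound 4 rests on compound 2 alone, and a step of a 1.3-fold higher number from compound 2 to compound 4 (0.12 log units; within the scatter) is expected in this assay. For compound 4 the estimate is 40000 nM, expected to fall between 12000 nM and 130000 nM.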

Compound 4, half-maximal inhibitory concentration: 31600 nM
Compound 4: the middle estimate sits 1.3-fold (0.10 log units) above what was measured; the measured number falls inside the stated range.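

In this assay, iodo in place of chloro on an aromatic carbon, meta to a large group, gives a 1.0-fold higher number from compound 2 to compound 4 (0.02 log units; within the scatter), so at this place the exchange leaves the read-out within the scatter. The same exchange on the core of compound 1 gives a step that cannot be read, and the two steps therefore cannot be set side by side: the limit of > 100000 nM in this assay, at which 2 of the 4 values shown sit. The series thus offers a single readable instance of this change, which shows that the estimate carried from compound 2 was compatible with the result but does not show that the change behaves alike on both cores.

The compounds shown leave open whether a group other than chloro or iodo at this place, such as an amine, a carboxylic acid or a longer chain, would shift the number in this assay. They also leave open how iodo in place of chloro would read on the core of compound 1 if both compounds gave numbers rather than limits.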